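This account rests on a few compounds, and the source may have more. Where it says the series, first, only, none or still open, it means among the compounds named here.

Measured so far in an assay (Equus caballus) for inhibition of Thromboxane-A synthase (Homo sapiens), using microsomes; on this read-out higher numbers stand for weaker inhibition and lower numbers for stronger inhibition:
compound 1 `CSC(CCC/C=C(\c1ccccc1)c1cccnc1)C(=O)O`, 30 nM
compound 2 `CC(C)(O)C(CCC/C=C(\c1ccccc1)c1cccnc1)C(=O)O`, 42 nM
compound 3 `O=C(O)CCCCCCCCC/C=C(/c1ccccc1)c1cccnc1`, 520 nM

On these three numbers compound 2 stands second highest. Its nearest neighbour is compound 1, which differs from it only at the saturated chain carbon bound to the carbonyl carbon and a saturated chain carbon; compound 3, with a longer chain and no group at that carbon, lies furthest away and well beyond the scatter. Among the measured compounds shown here, the one single-point step in the set, a 1.4-fold higher number from compound 1 to compound 2 (0.15 log units; within the scatter), shows that two very different groups at this carbon give numbers that cannot be told apart.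

Compound 4 `C=CCC(CCC/C=C(\c1ccccc1)c1cccnc1)C(=O)O` has not yet been measured in this assay. It differs from compound 2 as follows: allyl in place of 1-hydroxy-1-methylethyl on a saturated chain carbon bound to a carbonyl carbon and a saturated chain carbon. The step from compound 1 to compound 2 is the only measured one that bears on this change, and it stayed within the scatter. Compound 3 is not comparable at this position and so gives no guidance. No step beyond the scatter is therefore expected for compound 4.

Compound 4 is estimated at 40 nM, with a range from 15 nM to 110 nM. That estimate means an expected step of a 1.1-fold lower number from compound 2 to compound 4 (0.02 log units; within the scatter).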

Compound 4, half-maximal inhibitory concentration: 50 nM
The estimate for compound 4 lay 1.3-fold (0.10 log units) below the measured number, and the stated range covers the measured number.
By their numbers in this assay, from the lowest: compounds 1, 2 and 4 (each within the scatter of the next); then compound 3.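

In this assay, allyl at the saturated chain carbon bound to a carbonyl carbon and a saturated chain carbon gives a 1.2-fold higher number from compound 2 to compound 4 (0.08 log units; within the scatter), and the same group set against methylsulfanyl gives a 1.7-fold higher number from compound 1 to compound 4 (0.22 log units; within the scatter). Three groups at this carbon now stay within the scatter of one another, and the set extends to a group that is all carbon, with 0 hydrogen-bond donors and 0 hydrogen-bond acceptors, so neither the oxygen of 1-hydroxy-1-methylethyl nor the sulfur of methylsulfanyl is needed to stay within that scatter. The compounds shown offer no measurement that would account for this lack of separation.

Going by these compounds, it remains open whether an amine, a second carboxylic acid or a phenyl group at this carbon would also stay within the scatter of these three. Whether any group is needed here is also unresolved: compound 3 has no group at this carbon but also carries a longer chain, and the parent chain of compound 4 with plain hydrogen at this carbon is not among the compounds shown.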